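The compounds below may be only part of what the source reports. "The series", "measured", "known", "first", "only" and "open" are said of these compounds alone.

Compounds measured so far:
compound 1 `COc1cc(-c2nn(-c3cccc(NC(=O)c4cccc(C(F)(F)F)c4)c3)cc2-c2ccncc2)ccc1Cl` — 3850 nM
compound 2 `O=C(Nc1cccc(-n2cc(-c3ccncc3)c(-c3ccc(Cl)c(O)c3)n2)c1)Nc1cc(C(F)(F)F)cc(C(F)(F)F)c1` — 2510 nM
compound 3 `O=C(Nc1cccc(-n2cc(-c3ccncc3)c(-c3ccc(Cl)c(O)c3)n2)c1)Nc1ccc(Cl)c(C(F)(F)F)c1` — 2500 nM

In a functional assay on NCI-H522 cells (Homo sapiens) for inhibition, read by sulforhodamine B assay, with a stated time of 48 h (a higher number here means a weaker inhibitor of growth, a lower number a stronger inhibitor of growth), compound 1 gives 3850 nM, the highest number of the three, though its gaps to compound 2 and compound 3 both lie within the scatter of the assay, so no ordering among them can be read from these values. Compound 4 `COc1cc(-c2nn(-c3cccc(NC(=O)Nc4ccc(Cl)c(Cl)c4)c3)cc2-c2ccncc2)ccc1Cl` has not yet been measured. It differs from compound 1 in one place: (3,4-dichlorophenyl)amino in place of 3-(trifluoromethyl)phenyl on a carbonyl carbon. Within the data shown here, no pair of measured compounds differing in only one place is available, so the size of this change has no direct precedent here. Since compound 2 and compound 3, which carry related amino-bearing carbonyl groups, give values close to that of compound 1, the step of a 1.4-fold lower number from compound 1 to compound 4 (0.14 log units; within the scatter) is expected to be small, if any, toward a slightly lower number. Compound 4 is therefore estimated at 2800 nM, with a range from 1200 nM to 6500 nM.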

Compound 4, concentration for total growth inhibition: 3100 nM
Compound 4: middle estimate off by 1.1-fold (0.04 log units), on the low side; low and high end bracket the measured number.
By their numbers in this assay, from the lowest: compounds 3, 2, 4 and 1 (each within the scatter of the next).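

In this assay, placing (3,4-dichlorophenyl)amino in place of 3-(trifluoromethyl)phenyl on a carbonyl carbon gives a 1.2-fold lower number from compound 1 to compound 4 (0.09 log units; within the scatter). This first one-place comparison shows that the assay does not separate the (3-(trifluoromethyl)phenyl)carbonyl and (3,4-dichlorophenyl)carbamoyl forms on the core of compound 1. No measurement available here bears on why the two read alike.

On these data alone, whether this holds for a morpholine or a carboxylic acid-bearing phenyl on the same carbonyl carbon remains open.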